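Swapping the chain amine from compound 2 to compound 4

A few compounds are considered here, and "the series" means these few. Any claim that something is new, unique, unknown or untested is made for them only; others in the source may bear on it.

In a functional assay on MDA-MB-231 cells (Homo sapiens) for antiproliferative activity, read by MTT assay, with a stated time of 24 h (on this read-out higher numbers stand for weaker inhibition and lower numbers for stronger inhibition), compound 1 (`CCCCc1oc2ccccc2c1C(=O)c1cc(I)c(OCCCN2CCCCC2)c(I)c1`) gives 15700 nM and compound 2 (`CCCCc1oc2ccccc2c1C(=O)c1cc(I)c(OCCCN2CCN(CC)CC2)c(I)c1`) gives 18000 nM while compound 3 (`CCCCc1oc2ccccc2c1C(=O)c1cc(I)c(OCCCN2CCN(Cc3ccccc3)CC2)c(I)c1`) gives 15700 nM on the shared core. Compound 2 therefore stands level with both other compounds, all three lying within the scatter of one another.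

Compound 4 (`CCCCc1oc2ccccc2c1C(=O)c1cc(I)c(OCCCNCc2ccccc2)c(I)c1`) differs from compound 2 by one exchange (benzylamino in place of 4-ethylpiperazin-1-yl on a saturated chain carbon, three bonds along the chain from an oxygen on an aromatic ring), with benzylamino in place of 4-ethylpiperazin-1-yl on a saturated chain carbon. Going by the values given here, two measured steps bear on it: a 1.1-fold higher number from compound 1 to compound 2 (0.06 log units; within the scatter) and a 1.1-fold lower number from compound 2 to compound 3 (0.06 log units; within the scatter) are both within the scatter. Among the compounds with values here, neither step involves benzylamino, and no measured compound carries that group, so the guidance is indirect and the range is kept wide.

On those two steps, the expected change is a 1.2-fold lower number from compound 2 to compound 4 (0.08 log units; within the scatter) and no step beyond the scatter is expected in either direction. For compound 4 the estimated value is 15000 nM with an expected range of 7000 nM to 30000 nM in this series.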

Compound 4, half-maximal inhibitory concentration: 11600 nM
Estimate against measurement, compound 4: 1.3-fold (0.11 log units) above; the range from low to high includes it.
By their numbers in this assay, from the lowest: compounds 4, 1, 3 and 2 (each within the scatter of the next).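

In this assay, the steps of a 1.6-fold lower number from compound 2 to compound 4 (0.19 log units; within the scatter) and a 1.4-fold lower number from compound 1 to compound 4 (0.13 log units; within the scatter) extend the picture at this position, on a saturated chain carbon three bonds along the chain from an oxygen on an aromatic ring. Until now, only amines held in a six-membered non-aromatic ring stood here, whereas benzylamino moves that ring out to an aromatic ring of carbon only and brings in a hydrogen-bond donor, and both steps still lie within the scatter. Nothing available accounts for these steps or separates the contributions of the ring and the donor.

N-benzyl-N-methylamino at the same place would test the amine hydrogen apart from the benzyl group. On these data alone, whether a small open amine such as dimethylamino, or morpholin-4-yl, would leave the scatter also remains open.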